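A Methoxy for Fluoro Swap on the Sulfonamide Arm

This account rests on a few compounds, and the source may have more. Where it says the series, first, only, none or still open, it means among the compounds named here.

Compound 2 `CC1(CO/C(C(=O)Nc2cccc(Cl)c2)=C(/C=N)N2CCN(S(=O)(=O)NCc3ccc(N)c(F)c3)CC2)CC1` is measured in an ADME assay on cells (Hepatocyte, Rattus norvegicus) for pharmacokinetics (on this read-out lower numbers stand for slow clearance and higher numbers for fast clearance), where it gives 12.7 uL/min. Compound 1 `COc1ccc(CNS(=O)(=O)N2CCN(/C(C=N)=C(\OCC3(C)CC3)C(=O)Nc3cccc(Cl)c3)CC2)cc1N` gives 15 uL/min in this assay, so the two values sit within the scatter of each other; the step of a 1.2-fold lower number from compound 1 to compound 2 (0.07 log units; within the scatter) changed which groups decorate that phenyl ring. Compound 3 `COc1cc(CNS(=O)(=O)N2CCN(/C(C=N)=C(\OCC3(C)CC3)C(=O)Nc3cccc(Cl)c3)CC2)ccc1N` differs from compound 2 by methoxy in place of fluoro on an aromatic carbon. Among the compounds with values here, the only comparable step is the one from compound 1 to compound 2, which was within the scatter, so no change beyond the scatter is expected for compound 3 in this assay. Compound 3 is therefore estimated at 14 uL/min, ranging from 7 uL/min to 28 uL/min, an expected step of a 1.1-fold higher number from compound 2 to compound 3 (0.04 log units; within the scatter).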

Compound 3, intrinsic clearance in a liver preparation (reported as CLH), per the amount of preparation that the assay uses: 12.6 uL/min
For compound 3 the middle estimate is 1.1-fold (0.05 log units) above the measured one; the measured number falls inside the stated range.
By their numbers in this assay, from the lowest: compounds 3, 2 and 1 (each within the scatter of the next).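

In this assay, methoxy in place of fluoro on the aromatic carbon ortho to the amino group gives a 1.0-fold lower number from compound 2 to compound 3 (0.00 log units; within the scatter) as its step. Changing 3-amino-4-methoxyphenyl to 4-amino-3-methoxyphenyl gives a 1.2-fold lower number from compound 1 to compound 3 (0.08 log units; within the scatter) as its step, so among these compounds neither the fluoro-to-methoxy swap nor the rearranged ring separates the numbers. No measured evidence here explains this result. Open, as far as these compounds go, is whether a carboxylic acid or a longer chain such as butoxy on this carbon would move the number in this assay beyond the scatter.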